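Fluoro for chloro on the most permeable compound so far

The source may report more compounds than this note shows. Statements on the series, on what has been measured and on what is new or still open speak of the compounds shown alone.

Among the compounds with values here, in an ADME assay for permeability, using PAMPA, at pH 7.4 (a lower number here means that the compound crosses the layer more slowly, a higher number that the compound crosses the layer faster), compound 2 `Cc1[nH]c2ccc(Cl)cc2c(=O)c1Br` gives 87.7 10^-6 cm/s, the higher of the two numbers measured so far. Compound 1 `COc1ccc2[nH]c(C)c(Br)c(=O)c2c1` gives 16.7 10^-6 cm/s. Compound 3 `Cc1[nH]c2ccc(F)cc2c(=O)c1Br` keeps the shared core and differs from compound 2 in one place: fluoro in place of chloro on an aromatic carbon. In words, this is fluoro in place of chloro on an aromatic carbon.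

Within the data shown here, only one measured step bears on this change: a 5.3-fold higher number from compound 1 to compound 2 (0.72 log units; beyond the scatter), with chloro in place of methoxy on an aromatic carbon. Among the measured compounds shown here, no fluoro compound has been measured yet, so this single step is a loose guide. A smaller step than that one is expected, probably downward and perhaps no larger than the usual scatter. The expected step is a 1.6-fold lower number from compound 2 to compound 3 (0.20 log units; within the scatter). For compound 3 the estimated value is 55 10^-6 cm/s, with an expected range from 25 10^-6 cm/s to 110 10^-6 cm/s.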

Compound 3, apparent permeability: 18.3 10^-6 cm/s
For compound 3 the middle estimate is 3.0-fold (0.48 log units) above the measured one, outside the stated range (below it).
By their numbers in this assay, from the lowest: compounds 1 and 3 (each within the scatter of the next); then compound 2.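

In this assay this aromatic carbon proves sensitive even to an exchange of one halogen for another: fluoro in place of chloro gives a clear drop (a 4.8-fold lower number from compound 2 to compound 3 (0.68 log units; beyond the scatter)). Fluoro in place of methoxy gives no readable change (a 1.1-fold higher number from compound 1 to compound 3 (0.04 log units; within the scatter)), so compound 1 and compound 3 cannot be told apart, and among the three groups seen here only chloro, in compound 2, stands apart from the other two. Nothing measured here explains why chloro differs from both fluoro and methoxy.

On these data alone, whether any other group at this place would match chloro or fall back with fluoro and methoxy remains open, for example a nitrile, an amine or a carboxylic acid. Also open, as far as these compounds go, is whether the same ranking would hold if a longer chain were added elsewhere on the shared core.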